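Benzothiazolyl benzamides against hepatoma cell growth

The compounds below may be only part of what the source reports. "The series", "measured", "known", "first", "only" and "open" are said of these compounds alone.

Measured compounds:
- compound 1 `COc1ccc2sc(NC(=O)c3ccc(C(F)(F)F)cc3)nc2c1`: > 10 ug/mL
- compound 2 `COc1ccc(C(=O)Nc2nc3c(OC)cccc3s2)cc1`: 2.11 ug/mL
- compound 3 `Cc1cc(C)c2sc(NC(=O)c3ccc(C#N)cc3)nc2c1`: 1.18 ug/mL

Compound 1 is the weakest point in the set as far as the numbers go: in a functional assay on SK-HEP1 cells (Homo sapiens) for antiproliferative activity, read by sulforhodamine B assay (on this read-out lower numbers stand for stronger inhibition of growth and higher numbers for weaker inhibition of growth), compound 1 gives only a limit, > 10 ug/mL, so no number is known for it. This is the limit at which one of the three values sits (the limit of > 10 ug/mL in this assay, at which 1 of the 3 values shown sits). Compound 2 gives 2.11 ug/mL and compound 3 gives 1.18 ug/mL in this assay; both are real numbers and both lie well inside the measured range.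

Compound 4 `COc1ccc(C(=O)Nc2nc3cc(OC)ccc3s2)cc1` is not yet measured. It differs from compound 1 in one place: methoxy in place of trifluoromethyl on an aromatic carbon. Compound 2 carries the same methoxy on the benzamide side and a methoxy elsewhere on the shared core, and compound 2 gives 2.11 ug/mL. Compound 1 stands only at a limit, so the size of the step to compound 4 cannot be fixed from one side. The expectation is that the number drops beyond the scatter, roughly an at least 3.3-fold lower number from compound 1 to compound 4 (0.52 log units; beyond the scatter), given that compound 2 gives 2.11 ug/mL. Compound 4 is therefore expected near 3 ug/mL, with a plausible range from 1 ug/mL to 12 ug/mL.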

Compound 4, concentration for 50% growth inhibition: > 10 ug/mL
Compound 4: a limit, no number; the forecaster's own chance of this, stated with the estimate: 25%; at least 3.3-fold (0.52 log units) between middle value and limit.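

In this assay compound 1 and compound 4 both stand at a limit and not at a number, so no step can be read between them: the limit of > 10 ug/mL in this assay, at which 2 of the 4 values shown sit.

The compounds shown leave open what number either compound would give, and whether methoxy in place of trifluoromethyl on an aromatic carbon changes growth inhibition at all.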